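The source may hold more compounds than are shown below. What is called first, only, known or untested is meant among the compounds shown, and "the series" means these compounds.

Working notes on a small set of 2-methylthio / methylseleno quinazoline-type amines and one related azaquinazoline, all run in an ADME assay on 184B5 cells (Homo sapiens) for cytotoxicity, read by MTT assay, with a stated time of 72 h; a lower number here means a stronger inhibitor of growth, a higher number a weaker inhibitor of growth.

Compound 1 `C[Se]c1nc(N)c2ccccc2n1` gives 59000 nM in this assay. Compound 2 `COc1ccc(CNc2nc(SC)nc3ncccc23)cc1` gives 69800 nM in this assay; these two values show no difference worth reading. Compound 3 `CSc1nc(NCCCCCO)c2ccccc2n1` is the weakest point of the set as far as the numbers go: in this assay compound 3 gives only a limit, > 100000 nM, so its true value is not known beyond that. Among the measured compounds shown here, the same limit, (the limit of > 100000 nM in this assay, at which 1 of the 3 values shown sits), is the only evidence there is on the upper end of the range covered here. For the measured compounds named here, no step between two measured compounds is available, so nothing yet shows how a change on the chain carried by the ring nitrogen moves the read-out.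

Compound 4 `CSc1nc(NCCCc2ccccc2)c2ccccc2n1` differs from compound 3 by phenyl in place of 2-hydroxyethyl on a saturated chain carbon, three bonds along the chain from a nitrogen on an aromatic ring. On the numbers shown, the expectation for compound 4 is a moderate move toward stronger growth inhibition, an at least 1.6-fold lower number from compound 3 to compound 4 (0.22 log units; that floor lies within the scatter), since compound 3 sits at the limit > 100000 nM and both numbered values, compound 1 at 59000 nM and compound 2 at 69800 nM, lie in the same broad region. Compound 4 is therefore estimated at 60000 nM, within 20000 nM to 100000 nM, with a real chance that only a limit is reported again.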

Compound 4, concentration for total growth inhibition: > 100000 nM
Compound 4: a limit, no number; the forecaster's own chance of this, stated with the estimate: 35%; at least 1.6-fold (0.22 log units) between middle value and limit.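

Compound 4 gives > 100000 nM, a limit and not a number. Compound 3 also stands at a limit, so no step can be read from compound 3 to compound 4. The upper end of the range rests on limits alone: the limit of > 100000 nM in this assay, at which 2 of the 4 values shown sit. The compounds shown leave open whether 3-hydroxypropyl to benzyl moves growth inhibition at all, and in which direction.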